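Swapping trifluoromethyl for nitro on an aromatic ring

The source may hold more compounds than are shown below. What is called first, only, known or untested is meant among the compounds shown, and "the series" means these compounds.

In a functional assay on MOLT-4 cells (Homo sapiens) for cytotoxicity, read by CCK-8 assay, with a stated time of 24 h (on this read-out lower numbers stand for stronger inhibition and higher numbers for weaker inhibition), compound 1 `C=CC(=O)N1C(=O)CC(c2ccc(C(F)(F)F)cc2)Sc2ccccc21` gives 76300 nM. Compound 3 `C=CC(=O)N1C(=O)CC(c2ccccc2C(F)(F)F)Sc2ccccc21` gives 84400 nM, within the usual scatter of compound 1, so these two share the low end of the numbers. Compound 2 `C=CC(=O)N1C(=O)CC(C)Sc2ccccc21` gives 730000 nM, a clearly higher number and so a weaker result. Compound 4 `C=CC(=O)N1C(=O)CC(c2ccc([N+](=O)[O-])cc2)Sc2ccccc21` keeps the core of compound 1, with nitro in place of trifluoromethyl on an aromatic carbon, para to a large group: nitro in place of trifluoromethyl on an aromatic carbon. Among the compounds with values here, no measured pair shows this swap directly, so the expectation in this assay is no step beyond the scatter, in either direction. The estimated change is a 1.1-fold lower number from compound 1 to compound 4 (0.04 log units; within the scatter). Compound 4 is expected at 70000 nM, within a range of 30000 nM to 160000 nM.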

Compound 4, half-maximal inhibitory concentration: 91500 nM
Compound 4: the middle estimate sits 1.3-fold (0.12 log units) below what was measured, within the range that was stated.
By their numbers in this assay, from the lowest: compounds 1, 3 and 4 (each within the scatter of the next); then compound 2.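

In this assay nitro in place of trifluoromethyl on an aromatic carbon, para to a large group, gives a 1.2-fold higher number from compound 1 to compound 4 (0.08 log units; within the scatter) and so offers the first direct view of a swap at this position. In this read-out the two groups cannot be told apart, although nitro brings hydrogen-bond acceptors and trifluoromethyl brings none. No measurement at hand bears on this result. Going by these compounds, whether an amine or a carboxylic acid at this place would also stay within the scatter of compound 1 remains open. Also open, on these data alone, is whether nitro would match trifluoromethyl at the place that group holds in compound 3.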